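Heteroaryl replacements on the shared core

The source may hold more compounds than are shown below. What is called first, only, known or untested is meant among the compounds shown, and "the series" means these compounds.

Within the data shown here, compound 3 `CCC(C)(C)Cc1c[nH]c(CCc2ccc(-c3csnn3)cc2)n1` gives 11 nM in a functional assay on HEK293 cells for agonist activity at Bombesin receptor subtype-3 (Mus musculus), read by luminescence and calcium flux, with a stated time of 10 min (on this read-out lower numbers stand for an effect already at smaller amounts and higher numbers for an effect only at larger amounts of compound), the second highest of the three numbers so far; compound 2 `CCC(C)(C)Cc1c[nH]c(CCc2ccc(-n3cccn3)cc2)n1` gives 9 nM and compound 1 `CCC(C)(C)Cc1c[nH]c(CCc2ccc(-c3cccc(C)n3)cc2)n1` gives 19 nM. Both neighbours lie within the scatter of compound 3: a 1.2-fold higher number from compound 2 to compound 3 (0.09 log units; within the scatter) and a 1.7-fold lower number from compound 1 to compound 3 (0.24 log units; within the scatter). Compound 4 `CCC(C)(C)Cc1c[nH]c(CCc2ccc(-c3cnsc3)cc2)n1` carries 1,2-thiazol-4-yl in place of 1,2,3-thiadiazol-4-yl on an aromatic carbon. Among the measured compounds shown here, the steps that bear on this change are the earlier exchanges of the group at the same place, a 2.1-fold lower number from compound 1 to compound 2 (0.32 log units; beyond the scatter), a 1.7-fold lower number from compound 1 to compound 3 (0.24 log units; within the scatter) and a 1.2-fold higher number from compound 2 to compound 3 (0.09 log units; within the scatter), all small; three different groups here gave numbers in a narrow band. The same is therefore expected for this exchange, with no step beyond the scatter: no change at the digits printed from compound 3 to compound 4 (within the scatter). Compound 4 is estimated at 11 nM in this assay, within 5 nM to 25 nM.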

Compound 4, half-maximal effective concentration: 6.9 nM
Estimate against measurement, compound 4: 1.6-fold (0.20 log units) above, within the range that was stated.
By their numbers in this assay, from the lowest: compounds 4, 2, 3 and 1 (each within the scatter of the next, the first and the last beyond it).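

In this assay, going from three hetero atoms to two in the five-membered ring gives a 1.6-fold lower number from compound 3 to compound 4 (0.20 log units; within the scatter), so this change at this place leaves the number unresolved from that of compound 3, and a 1.3-fold lower number from compound 2 to compound 4 (0.12 log units; within the scatter) shows the same for the 1H-pyrazol-1-yl group. The widest gap so far is a 2.8-fold lower number from compound 1 to compound 4 (0.44 log units; beyond the scatter), which puts 1,2-thiazol-4-yl with 1H-pyrazol-1-yl in separating from 6-methylpyridin-2-yl, while compound 3 goes against that split. No measurement shown offers an explanation for these steps.

Open, as far as these compounds go, is whether an amine or a carboxylic acid at this place stays in the same narrow band. Also open, from the compounds shown here alone, is whether the methyl or the six-membered ring of 6-methylpyridin-2-yl sets compound 1 apart.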